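Chloro to Bromo on the Urea Aryl Ring

A few compounds are considered here, and "the series" means these few. Any claim that something is new, unique, unknown or untested is made for them only; others in the source may bear on it.

Three compounds share one urea core built from the same atoms. Compound 1 `C[C@@H](NC(=O)Nc1ccccc1Cl)c1ccccc1` carries chloro on an aromatic carbon of a six-membered aromatic ring of carbon only, ortho to a large group. In an ADME assay on the whole organism with Oryza sativa as the target, tested at 10 uM (a lower number here means a stronger effect, a higher number a weaker effect of the compound at the concentration tested), compound 1 gives 93%. Compound 3 `C[C@@H](NC(=O)Nc1ccccc1Br)c1ccccc1` differs from it by bromo in place of chloro on an aromatic carbon, and in this assay compound 3 gives 94%; the step is a number 1 percentage points higher from compound 1 to compound 3 (within the scatter). Compound 2 `C[C@@H](NC(=O)Nc1cccc(Cl)c1)c1ccccc1` has the same atoms as compound 1, joined differently; the difference between the two cores is not broken down here. In this assay compound 2 gives 83%, which lies within the scatter of compound 1 and beyond the scatter of compound 3.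

Compound 4 `C[C@@H](NC(=O)Nc1cccc(Br)c1)c1ccccc1` has not yet been measured in this assay. It differs from compound 2 by bromo in place of chloro on an aromatic carbon. Among the measured compounds shown here, this is the same kind of change as the one from compound 1 to compound 3, but the place is not the same: in compound 2 and compound 4 the aromatic carbon is meta to a large group, whereas in compound 1 and compound 3 it is ortho to a large group. The step is expected to be of like size, a number 1 percentage points higher from compound 2 to compound 4 (within the scatter), because a number 1 percentage points higher from compound 1 to compound 3 (within the scatter) stayed within the scatter. Compound 4 is therefore estimated at 84%, between 75% and 93%, resting on compound 2 with 83%.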

Compound 4, a percentage reported as activity, at one concentration (the size of the read-out at that concentration, not a potency): 99%
Compound 4: the middle estimate sits 15 percentage points below what was measured; measured number outside the range, above it.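

In this assay, bromo in place of chloro on an aromatic carbon meta to a large group gives a number 16 percentage points higher from compound 2 to compound 4 (beyond the scatter), so the swap that seemed to change almost nothing on the core of compound 1 does change the read-out on the core of compound 2. The step therefore cannot simply be carried from one core to the other in this series, as the two cores give clearly different answers for the same change: the same change on two cores in this assay, a number 1 percentage points higher (within the scatter) from compound 1 to compound 3 and a number 16 percentage points higher (beyond the scatter) from compound 2 to compound 4, 15 percentage points apart, beyond the scatter of two such steps. This does not show why the two steps differ, and with a single pair on each core it gives no rule for how the swap would behave on any further core, nor does it say which feature of the two cores matters.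

The compounds shown leave open how other groups would read on these two cores, for instance fluoro, a methyl group or a methoxy group on the same aromatic carbon, and whether any of them would also give different steps on the two cores. They also leave open whether a repeat of the bromo and chloro pairs would return steps of the same size.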